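Moving one methoxy group on the saturated-carbon aryl ring

The source may hold more compounds than are shown below. What is called first, only, known or untested is meant among the compounds shown, and "the series" means these compounds.

Of the compounds shown here, three have so far been tested in a functional assay on BGC-823 cells (Homo sapiens) for antiproliferative activity, read by MTT assay, tested at 1 uM; on this read-out lower numbers stand for a weaker effect and higher numbers for a stronger effect at the one concentration tested. Compound 1 `COc1ccc(C2OC(c3cc(OC)c(OC)c(OC)c3)=NN2C(C)=O)c(OC)c1` gives 6.3% in this assay. Compound 2 `COc1cc(C(=O)N/N=C/c2cccc(C(F)(F)F)c2)cc(OC)c1OC` gives 17.7%, and compound 3 `COc1cc(C(=O)N/N=C/c2ccc(Cl)c([N+](=O)[O-])c2)cc(OC)c1OC` gives -5.8%. Among these three numbers compound 1 stands second highest: compound 2 lies above it by more than the usual scatter, and compound 3 lies below it by more than the usual scatter. Both of those compounds differ from compound 1 in several places at once, so neither gap can be tied to a single structural change.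

Compound 4 `COc1cc(C2=NN(C(C)=O)C(c3cccc(OC)c3OC)O2)cc(OC)c1OC` is not yet measured. It differs from compound 1 in one place, and the two have the same atoms, joined differently: 2,3-dimethoxyphenyl in place of 2,4-dimethoxyphenyl on a saturated ring carbon

Going by the values given here, no measured pair isolates a change of this kind, so the expectation rests on the change being small. The step of a number 1.7 percentage points higher from compound 1 to compound 4 (within the scatter) is expected to be none beyond the scatter. Compound 4 is therefore estimated at 8%, within a range from -8% to 24%.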

Compound 4, a percentage reported as inhibition, at one concentration (the size of the read-out at that concentration, not a potency): 3.8%
The estimate for compound 4 lay 4.2 percentage points above the measured number; low and high end bracket the measured number.
By their numbers in this assay, from the lowest: compounds 3, 4 and 1 (each within the scatter of the next, the first and the last beyond it); then compound 2.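

In this assay, going by these compounds alone, the swap of 2,4-dimethoxyphenyl for 2,3-dimethoxyphenyl on a saturated ring carbon gives a number 2.5 percentage points lower from compound 1 to compound 4 (within the scatter) and this is the first comparison here in which only one place differs. At this position, then, these two arrangements of the same two methoxy groups cannot be told apart at the one concentration tested. Nothing available explains this outcome or gives a measured property of either group.

The compounds shown leave open whether a different kind of group on this aryl ring, such as an amine or a carboxylic acid, would shift the number beyond the scatter. They also leave open what a longer chain in place of the acetyl group would do on the same core.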